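This account rests on a few compounds, and the source may have more. Where it says the series, first, only, none or still open, it means among the compounds named here.

Measured compounds:
- Compound 1 `O=C(Nc1cc(F)cc2cccnc12)c1ncccn1`: > 10000 nM
- Compound 2 `NCCOc1cc(NC(=O)c2cnccn2)c2ncccc2c1`: > 10000 nM
- Compound 3 `CC(C)(C)OC(=O)NCCOc1cc(NC(=O)c2ncccn2)c2ncccc2c1`: > 10000 nM

Three compounds of the series have been run in a functional assay on BXPC-3 cells (Homo sapiens) for inhibition, read by MTT assay, with a stated time of 72 h (on this read-out higher numbers stand for weaker inhibition and lower numbers for stronger inhibition), and none returned a number. Compound 1 sits at the limit of this assay. Compound 2 likewise gives only a limit. Compound 3 is also reported as a limit only, so its standing cannot be placed above or below the other two; all that is known is that the three shown values sit together at the limit (the limit of > 10000 nM in this assay, at which 3 of the 3 values shown sit).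

Compound 4 `NCCOc1cc(NC(=O)c2ncccn2)c2ncccc2c1` is not yet measured. It differs from compound 3 by hydrogen in place of tert-butoxycarbonyl on an amine nitrogen. No step between measured compounds is shown, so nothing in these data tells what removing the tert-butoxycarbonyl does to inhibition; compound 2, which also carries a free amine on its chain, shows only a limit, and compound 3 with the carbamate shows the same. The step from compound 3 to compound 4 is therefore expected to be a step that the limit leaves unreadable from compound 3 to compound 4, that is, nothing resolvable beyond the scatter. Compound 4 is estimated at 20000 nM, within 8000 nM to 60000 nM, most likely again reported only as a limit.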

Compound 4, half-maximal inhibitory concentration: > 10000 nM
Compound 4: only a limit was reported (the forecaster's own chance of this, stated with the estimate: 85%); the middle value does not contradict the limit.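

In this assay compound 4 gives > 10000 nM, a limit and not a number. Among the compounds shown here, no step to compound 4 from compound 1, compound 2 or compound 3 can be read, as all four compounds stand at a limit. The compounds shown leave open which change to the shared core, if any, would give a measurable value in this assay.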